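Ester to Acid on the Side Chain of an Adenosine Deaminase Inhibitor

The source may report more compounds than this note shows. Statements on the series, on what has been measured and on what is new or still open speak of the compounds shown alone.

Of the compounds shown here, two measured so far share a common core and a side chain ending in a substituted phenyl group. Compound 1 `C[C@H](O)[C@@H](CCc1ccc(C(F)(F)F)cc1)n1cnc2c(N)ncnc21` carries a trifluoromethyl group on that ring; in an assay on isolated protein for inhibition of adenosine deaminase (Bos taurus), with a stated time of 5 min (a higher number here means a weaker inhibitor, a lower number a stronger inhibitor), compound 1 gives 5.2 nM. Compound 2 `COC(=O)c1cccc(CC[C@H]([C@H](C)O)n2cnc3c(N)ncnc32)c1` instead carries a methoxycarbonyl group, and in this assay compound 2 gives 2.2 nM. That is the lower of the two numbers, and the difference to compound 1 lies beyond the usual scatter, so compound 2 stands as the stronger inhibitor of the pair.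

Compound 3 `C[C@H](O)[C@@H](CCc1cccc(C(=O)O)c1)n1cnc2c(N)ncnc21` has not yet been measured. It differs from compound 2 by hydrogen in place of methyl on an oxygen next to a carbonyl group; read one bond further out, methoxycarbonyl becomes carboxy. Within the data shown here, no measured pair shows what this particular change does here, so any expectation rests on the two values above and on the change itself. A modest step toward a higher number, somewhat beyond the scatter, is expected, namely a 3.2-fold higher number from compound 2 to compound 3 (0.50 log units; beyond the scatter). Compound 3 is expected to give about 7 nM, within a range of 2 nM to 30 nM.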

Compound 3, inhibition constant: 53 nM
Estimate against measurement, compound 3: 7.6-fold (0.88 log units) below; the whole stated range lies below it.
By their numbers in this assay, from the lowest: compound 2; then compound 1; then compound 3.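

Exchanging methyl for hydrogen on an oxygen next to a carbonyl group, which turns methoxycarbonyl into carboxy, removes only one heavy atom, yet in this assay it gives a large loss of inhibition (a 24-fold higher number from compound 2 to compound 3 (1.38 log units; beyond the scatter)). Among these compounds, this is the first change that can be read on its own, since no earlier pair differed in just one place, and it shows that this position is sensitive to even a very small edit. Nothing measured here accounts for the size of this step.

On these data alone, two compounds joined by one step cannot show whether the loss comes from gaining the hydrogen or from losing the methyl, so it remains open whether an ethyl ester or a primary amide in the same place would stay close to compound 2 or move toward compound 3. As far as these compounds go, it is equally open whether the same exchange would cost as much with a longer chain carrying the ring, or with the carboxylic acid attached at another place on that ring.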